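Nitrooxyalkyl cinnamate esters: methylation of the ring hydroxyl

The source may hold more compounds than are shown below. What is called first, only, known or untested is meant among the compounds shown, and "the series" means these compounds.

The series holds compound 1 `O=C(/C=C/c1ccc(OCCCCCO[N+](=O)[O-])c(O)c1)OCCCCCO[N+](=O)[O-]`, compound 2 `O=C(/C=C/c1ccc(OCCCCO[N+](=O)[O-])c(O)c1)OCCCCO[N+](=O)[O-]` and compound 3 `COc1cc(/C=C/C(=O)OCCCCCO[N+](=O)[O-])ccc1OCCCCCO[N+](=O)[O-]`, all measured, and compound 4 `COc1cc(/C=C/C(=O)OCCCCO[N+](=O)[O-])ccc1OCCCCO[N+](=O)[O-]`, not yet measured. The difference between the cores of compound 1 and compound 2 is not broken down here. In a functional assay on cells (Homo sapiens) for cytotoxicity, read by resazurin assay, with a stated time of 72 h (a lower number here means a stronger inhibitor, a higher number a weaker inhibitor), compound 1 gives > 50000 nM, which is a limit of the assay and not a number. In this assay compound 2 gives > 50000 nM, likewise a limit. In this assay compound 3 gives > 50000 nM, again a limit. The change methyl in place of hydrogen on an oxygen on an aromatic ring yields a step that the two limits leave unreadable from compound 1 to compound 3, as all values sit at the limit of > 50000 nM in this assay, at which 3 of the 3 values shown sit. The same change, (methyl in place of hydrogen on an oxygen on an aromatic ring), leads from compound 2 to compound 4. Expected for it here: a step that the limit leaves unreadable from compound 2 to compound 4, since a step that the two limits leave unreadable from compound 1 to compound 3 gives no readable size. Compound 4 is expected at 90000 nM, between 40000 nM and 250000 nM, most likely reported only as a limit.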

Compound 4, half-maximal inhibitory concentration: > 50000 nM
Compound 4 ended at the assay's limit; the forecaster's own chance of this, stated with the estimate: 90%; the middle value lies beyond the limit too.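

No new step can be read between compound 2 and compound 4, as the hydroxy to methoxy change stays hidden at the limit: the limit of > 50000 nM in this assay, at which 4 of the 4 values shown sit.

The compounds shown leave open what size this change has in this assay, and whether any compound of the series gives a value inside the assay's range.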